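The source may report more compounds than this note shows. Statements on the series, on what has been measured and on what is new or still open speak of the compounds shown alone.

Of the compounds shown here, three sharing one core have been measured in a functional assay on SGC-7901 cells (Homo sapiens) for antiproliferative activity, read by MTT assay, with a stated time of 24 h; a lower number here means a stronger inhibitor, a higher number a weaker inhibitor. Compound 1 `Cc1cccc(-n2cc(-c3cccc(NS(=O)(=O)c4c[nH]c(=O)[nH]c4=O)c3)nn2)c1` gives 9100 nM in this assay. Compound 2 `Cc1ccc(-n2cc(-c3ccc(NS(=O)(=O)c4c[nH]c(=O)[nH]c4=O)cc3)nn2)cc1` gives 8350 nM, and compound 3 `O=c1[nH]cc(S(=O)(=O)Nc2ccc(-c3cn(-c4ccccc4F)nn3)cc2)c(=O)[nH]1` gives 7270 nM. Compound 3 thus carries the lowest of the three numbers, yet its gaps to compound 2 and to compound 1 both lie within the scatter, so the three cannot be ordered with confidence. Within the data shown here, the only single-point step among them, a 1.1-fold lower number from compound 2 to compound 3 (0.06 log units; within the scatter), swaps one aryl group on the aromatic nitrogen for another and moves the number by less than the scatter.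

Compound 4 `O=c1[nH]cc(S(=O)(=O)Nc2ccc(-c3cn(-c4ccccc4Cl)nn3)cc2)c(=O)[nH]1` differs from compound 3 in one place: chloro in place of fluoro on an aromatic carbon. The step from compound 2 to compound 3 bears on this most closely, since it changed the same aryl group on the aromatic nitrogen that is now altered again, and that step was small. Compound 1 and compound 2, which differ in more than one place, also show numbers close to one another. Nothing among the three measured compounds points to a shift beyond the scatter, so for compound 4 the step of a 1.0-fold lower number from compound 3 to compound 4 (0.02 log units; within the scatter) is expected to be negligible. Compound 4 is therefore estimated at 7000 nM, most likely between 3500 nM and 14000 nM in this assay.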

Compound 4, half-maximal inhibitory concentration: 2680 nM
Estimate against measurement, compound 4: 2.6-fold (0.42 log units) above, outside the stated range (below it).
By their numbers in this assay, from the lowest: compound 4; then compounds 3, 2 and 1 (each within the scatter of the next).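

Chloro in place of fluoro on this aromatic carbon, ortho to a large group, gives a 2.7-fold lower number from compound 3 to compound 4 (0.43 log units; beyond the scatter) in this assay, so the aryl group on the aromatic nitrogen is not as insensitive as a 1.1-fold lower number from compound 2 to compound 3 (0.06 log units; within the scatter) alone had suggested. A change of one heavy atom here, with no change in the counted hydrogen-bond donors or acceptors, is enough to move the number beyond the scatter, and the 2-chlorophenyl group also stands apart from the 4-methylphenyl group, with a 3.1-fold lower number from compound 2 to compound 4 (0.49 log units; beyond the scatter) as the measured step. No measurement shown here accounts for the difference between chloro and fluoro at this position.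

What bromo, methoxy or an amine on that same carbon would give remains open, so the compounds shown cannot tell whether the gain belongs to chloro alone or extends to other groups. Also open, as far as these compounds go, is whether chloro on a different carbon of this ring, or the same change made on the aryl group of compound 1, would produce a step of similar size.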